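A Methoxy Group on the Fused Ring of Compound 1

The source may hold more compounds than are shown below. What is called first, only, known or untested is meant among the compounds shown, and "the series" means these compounds.

Compound 1 `CS(=O)(=O)c1ccc(Nc2nccc(Nc3nc4ccccc4s3)n2)cc1`: 8370 nM
Compound 2 `NS(=O)(=O)c1ccc(Nc2nccc(Nc3nc4ccccc4s3)n2)cc1`: 5170 nM

Both numbers come from a functional assay on HCT-116 cells (Homo sapiens) for antiproliferative activity, read by MTT assay, with a stated time of 48 h; a lower number here means a stronger inhibitor, a higher number a weaker inhibitor. In this assay compound 1 gives 8370 nM and compound 2 gives 5170 nM. The two numbers sit close together: the step of a 1.6-fold lower number from compound 1 to compound 2 (0.21 log units; within the scatter) is within the scatter, so compound 1 and compound 2 cannot be told apart in potency, and compound 1 simply marks the upper end of a pair of near-identical readings.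

Compound 3 `COc1ccc2nc(Nc3ccnc(Nc4ccc(S(C)(=O)=O)cc4)n3)sc2c1` differs from compound 1 by methoxy in place of hydrogen on an aromatic carbon. Among the compounds with values here, the only step measured so far, from compound 1 to compound 2, alters the group on the sulfonyl sulfur, a different part of the shared core, and it produced no change beyond the scatter. Within the data shown here, no measured step touches the fused ring, so there is nothing in hand that points to a shift in either direction for this change. The expectation is therefore no step beyond the scatter. Compound 3 is expected to give about 8000 nM, with a range from 3000 nM to 22000 nM. The expected step is a 1.0-fold lower number from compound 1 to compound 3 (0.02 log units; within the scatter), which would stay within the scatter.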

Compound 3, half-maximal inhibitory concentration: 2270 nM
Compound 3: middle estimate off by 3.5-fold (0.55 log units), on the high side; the measured number lies below the stated range.
By their numbers in this assay, from the lowest: compound 3; then compounds 2 and 1 (each within the scatter of the next).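

With this change the fused part of the molecule enters the comparison, and this assay shows a 3.7-fold lower number from compound 1 to compound 3 (0.57 log units; beyond the scatter), a modest step but one beyond the scatter, unlike the earlier step on the sulfonyl sulfur. The aromatic carbon carrying the methoxy, on the six-membered aromatic ring of carbon only, is therefore a place where a substituent can move the number, and here a methoxy of 2 heavy atoms in place of hydrogen lowers it rather than raises it. No measurement in hand explains how this single added group produces the step.

One substituent at one carbon cannot show whether the step needs the oxygen, the methyl on it, or simply any group at that place, and a hydroxyl, a fluorine, an ethoxy or an amine on the same carbon would begin to separate these possibilities. From the compounds shown here alone, it also remains open whether the methoxy would give a similar step on the core of compound 2, which carries the amino group on the sulfonyl sulfur, or at another carbon of the same ring.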